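A few compounds are considered here, and "the series" means these few. Any claim that something is new, unique, unknown or untested is made for them only; others in the source may bear on it.

In a functional assay on PC-3 cells (Homo sapiens) for antiproliferative activity, read by MTT assay, with a stated time of 48 h (a higher number here means a weaker inhibitor, a lower number a stronger inhibitor), compound 1 `N#Cc1cccc(Nc2ncnc3cc(NC(=O)/C=C/c4ccccc4)sc23)c1` gives 540 nM and compound 2 `O=C(/C=C/c1ccccc1)Nc1cc2c(Nc3ccc(Cl)c(Cl)c3)ncnc2s1` gives 480 nM while compound 3 `COc1ccc(/C=C/C(=O)Nc2cc3c(Nc4cc(Cl)cc(Cl)c4)ncnc3s2)cc1` gives 450 nM as its value. Compound 1 therefore stands level with the other two: all three numbers lie within the usual scatter of repeat measurements, so they cannot be ranked.

Compound 4 `O=C(/C=C/c1ccccc1)Nc1cc2ncnc(Nc3ccc(Cl)c(Cl)c3)c2s1` has not yet been measured. It keeps the core of compound 1 and its amide side chain, and it changes in one place: 3,4-dichlorophenyl in place of 3-cyanophenyl on a nitrogen on an aromatic ring. Among the compounds with values here, no measured pair shows this swap on its own. The nearest guide is compound 2, which carries the same 3,4-dichlorophenyl group on a differently arranged core and gives 480 nM in this comparison, level with compound 1 at 540 nM on these numbers. In this assay no step beyond the scatter is therefore expected, in either direction. The estimated change is small, with a 1.1-fold lower number from compound 1 to compound 4 (0.03 log units; within the scatter) as the expected step. For compound 4 the estimate is 500 nM with an expected range from 220 nM to 1150 nM around it.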

Compound 4, half-maximal inhibitory concentration: 260 nM
Estimate against measurement, compound 4: 1.9-fold (0.28 log units) above; measured number inside the range.
By their numbers in this assay, from the lowest: compounds 4, 3, 2 and 1 (each within the scatter of the next, the first and the last beyond it).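

In this assay, replacing 3-cyanophenyl with 3,4-dichlorophenyl on a nitrogen on an aromatic ring gives a 2.1-fold lower number from compound 1 to compound 4 (0.32 log units; beyond the scatter), while the core and the amide side chain stay the same. Within the data shown here, this is a modest step, but it is the first evidence that the group at this position can shift the number beyond the scatter, since no two of the earlier compounds differed in one place only and their values could not be ranked. No measurement of any property of these two groups accompanies the result, so the data show the size of the step but offer no explanation for it.

This single swap cannot show whether the two chlorines are both needed, or whether losing the nitrile alone accounts for the step, and a plain phenyl group and a phenyl carrying one chlorine would help to separate these possibilities. From the compounds shown here alone, it also remains open whether a phenyl carrying bromine or a methyl group would shift the number further, and whether the same swap would give a similar step on a different core.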